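The compounds below may be only part of what the source reports. "The series", "measured", "known", "first", "only" and "open" are said of these compounds alone.

The measured compounds and their values in a functional assay on the whole organism for inhibition, with Rattus norvegicus as the target, at a dose of 30 mg/kg; a higher number here means more inhibition at the dose given (going by the name of the read-out), a lower number less inhibition:
compound 1, `CCC/N=C(\S)n1ncnc1N`, gives 93%;
compound 2, `CCCC/N=C(\S)n1ncnc1N`, gives 21%;
compound 3, `CCCCCC/N=C(\S)n1ncnc1N`, gives -1%.

Compound 3 stands lowest of the three. Its nearest neighbour is compound 2, reached by the modest step of a number 22 percentage points lower from compound 2 to compound 3 (beyond the scatter); its furthest is compound 1, separated by the large step of a number 94 percentage points lower from compound 1 to compound 3 (beyond the scatter). The third measured step, a number 72 percentage points lower from compound 1 to compound 2 (beyond the scatter), points the same way: each time the chain running from the double-bonded nitrogen grows, inhibition falls, and compound 3 carries the longest chain of the three.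

Compound 4, `CCOCCC/N=C(\S)n1ncnc1N`, is not yet measured. It differs from compound 3 in one place: ethoxy in place of propyl on a saturated chain carbon, three bonds along the chain from a double-bonded nitrogen. The chain is not lengthened further; one carbon in it gives way to an oxygen. The three measured steps all concern chain length and say nothing about such an exchange. Because compound 3 already sits at -1%, little room remains for a further fall, and nothing measured suggests a return toward what compound 1 shows. The step of a number 11 percentage points higher from compound 3 to compound 4 (beyond the scatter) is therefore expected to be small, within the scatter. For compound 4 the expected value in this assay is 10%, with a range from -10% to 35%.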

Compound 4, a percentage reported as inhibition, in the whole organism at one dose (the size of the read-out at that dose, not a potency): 1%
Compound 4: the middle estimate sits 9 percentage points above what was measured; low and high end bracket the measured number.
By their numbers in this assay, from the lowest: compounds 3 and 4 (each within the scatter of the next); then compound 2; then compound 1.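

In this assay, ethoxy in place of propyl, on a saturated chain carbon three bonds along the chain from a double-bonded nitrogen, gives a number 2 percentage points higher from compound 3 to compound 4 (within the scatter) and so does not bring inhibition back at this position. Even with an oxygen in place of a carbon, this longer chain stays far from the shorter ones, with a number 20 percentage points lower from compound 2 to compound 4 (beyond the scatter) and a number 92 percentage points lower from compound 1 to compound 4 (beyond the scatter) as the printed steps. No measurement on hand accounts for this result.

As far as these compounds go, it remains open whether an amine or a carboxylic acid at the end of the chain would restore inhibition where ethoxy does not. A shorter ethyl chain or a branched isopropyl group in place of the chain of compound 1 would show how the shortest chain here compares with its nearest variants.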